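Indazolyl to indolyl swap on the fused bicyclic core

The compounds below may be only part of what the source reports. "The series", "measured", "known", "first", "only" and "open" are said of these compounds alone.

Measured compounds:
compound 1 `COc1cc(-c2ccnc3cc(-c4ccc(C(C)=O)cc4)nn23)cc(OC)c1OC` — in a functional assay on B16-F0 cells (Mus musculus) for inhibition, read by CCK-8 assay, with a stated time of 48 h (on this read-out lower numbers stand for stronger inhibition and higher numbers for weaker inhibition), compound 1 gives 3930 nM
compound 2 `COc1cc(-c2ccnc3cc(-c4ccc(N(C)C)cc4)nn23)cc(OC)c1OC` — in this assay compound 2 gives 702 nM
compound 3 `COc1cc(-c2ccnc3cc(-c4ccc5cnn(C)c5c4)nn23)cc(OC)c1OC` — in this assay compound 3 gives 1000 nM

Compound 3 holds the second highest of the three numbers in this assay. Its nearest neighbour is compound 2, a 1.4-fold higher number from compound 2 to compound 3 (0.15 log units; within the scatter), so the two are not told apart. Its furthest neighbour is compound 1, a 3.9-fold lower number from compound 1 to compound 3 (0.59 log units; beyond the scatter), a step beyond the scatter, as is a 5.6-fold lower number from compound 1 to compound 2 (0.75 log units; beyond the scatter).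

Compound 4 `COc1cc(-c2ccnc3cc(-c4ccc5c(ccn5C)c4)nn23)cc(OC)c1OC` is unmeasured. Its change from compound 3 is 1-methyl-1H-indol-5-yl in place of 1-methyl-1H-indazol-6-yl on an aromatic carbon.

Within the data shown here, no measured step replaces one fused bicyclic aryl with another; the two steps beyond the scatter both start from the acetyl-bearing phenyl of compound 1 and are modest. Among the measured compounds shown here, the one step between two non-acetyl aryl groups, from compound 2 to compound 3, stays within the scatter. On that basis no step beyond the scatter is expected in this assay for compound 4 against compound 3, and the expected step is no change at the digits printed from compound 3 to compound 4 (within the scatter), in either direction. Compound 4 is therefore estimated at 1000 nM, with a range from 400 nM to 2500 nM.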

Compound 4, half-maximal inhibitory concentration: 48 nM
Compound 4: middle estimate off by 21-fold (1.32 log units), on the high side, outside the stated range (below it).
By their numbers in this assay, from the lowest: compound 4; then compounds 2 and 3 (each within the scatter of the next); then compound 1.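

In this assay, among these compounds, the aryl group on this aromatic carbon proves able to shift the number far more than the earlier compounds showed: the swap of one fused bicyclic group for another gives a 21-fold lower number from compound 3 to compound 4 (1.32 log units; beyond the scatter), the first large step. The substituted phenyl groups also fall well short of 1-methyl-1H-indol-5-yl, with a 15-fold lower number from compound 2 to compound 4 (1.17 log units; beyond the scatter) and an 82-fold lower number from compound 1 to compound 4 (1.91 log units; beyond the scatter). A fused bicyclic group as such is not enough, since compound 3 stays within the scatter of compound 2, so the outcome depends on which bicyclic group sits here.

The swap changes a five-membered aromatic ring with 2 hetero atoms to one with 1 hetero atom and also moves the attachment from the 6-yl to the 5-yl form, and no measurement at hand bears on the reason for the gain. A 1-methyl-1H-indol-6-yl or a 1-methyl-1H-indazol-5-yl group would separate those two changes, and a 1H-indol-5-yl group without the methyl would show what that methyl contributes.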